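Alkyne to cyclopropylmethyl on the aryl ether of compound 2

The compounds below may be only part of what the source reports. "The series", "measured", "known", "first", "only" and "open" are said of these compounds alone.

Compound 1, `CCCCOc1cccc2ccc(N)nc12`, 789 nM
Compound 2, `CCC#CCOc1cccc2ccc(N)nc12`, > 2000 nM
Compound 3, `Nc1ccc2cccc(OCCC3CC3)c2n1`, not yet measured

In an assay on cells with melanin-concentrating hormone receptor 1 (Homo sapiens) as the target, read by radioligand binding (on this read-out higher numbers stand for weaker inhibition and lower numbers for stronger inhibition), compound 1 gives 789 nM. Compound 2 reaches only a limit of the assay, > 2000 nM, the limit (the limit of > 2000 nM in this assay, at which 1 of the 2 values shown sits), so its place among the numbers is known only as a range. Among the measured compounds shown here, the one measured step, an at least 2.5-fold higher number from compound 1 to compound 2 (0.40 log units; beyond the scatter), shows that introducing the triple bond weakened inhibition. Compound 3 carries the change (cyclopropylmethyl in place of but-1-yn-1-yl on a saturated chain carbon bound to an oxygen on an aromatic ring), which removes that triple bond and brings in a three-membered ring. A return toward the level of compound 1 is therefore expected, an at least 1.6-fold lower number from compound 2 to compound 3 (0.22 log units; that floor lies within the scatter). Compound 3 is estimated at 1200 nM, between 400 nM and 3000 nM.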

Compound 3, half-maximal inhibitory concentration: 492 nM
Compound 3: the middle estimate sits 2.4-fold (0.39 log units) above what was measured; low and high end bracket the measured number.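

In this assay, the weak result with the triple bond does not extend to every replacement at this place: cyclopropylmethyl in place of but-1-yn-1-yl gives an at least 4.0-fold lower number from compound 2 to compound 3 (0.60 log units; beyond the scatter). Cyclopropyl in place of ethyl, two bonds along the chain from an oxygen on an aromatic ring, gives a 1.6-fold lower number from compound 1 to compound 3 (0.21 log units; within the scatter), so the three-membered ring is accepted there without a change that can be read. The first step has only a floor, as compound 2 stands at a limit rather than a number: the limit of > 2000 nM in this assay, at which 1 of the 3 values shown sits.

Going by these compounds, what stays open is how an amine or a carboxylic acid at the end of this chain would compare. A longer chain or a cyclohexyl ring in the same place also remains untested among the compounds shown.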